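Anilino to (tert-butyl)amino at the assay limit

This account rests on a few compounds, and the source may have more. Where it says the series, first, only, none or still open, it means among the compounds named here.

Notes on the series: compound 1 `N#Cc1c(F)c(F)c2nc(N)nc(N)c2c1F`, compound 2 `N#Cc1c(Nc2ccccc2)c(Cl)c2nc(N)nc(N)c2c1F` and compound 3 `N#Cc1c(Nc2ccccc2)c(F)c2nc(N)nc(N)c2c1F` have been measured in a functional assay on A549 cells (Homo sapiens) for cytotoxicity, read by MTT assay (on this read-out higher numbers stand for weaker inhibition and lower numbers for stronger inhibition), and compound 4 `CC(C)(C)Nc1c(C#N)c(F)c2c(N)nc(N)nc2c1Cl` has not.

Compound 2 gives > 1000 ug/mL, which is a limit and not a number. Compound 1 gives > 1000 ug/mL, also a limit. Compound 3 gives > 1000 ug/mL, again a limit. The whole record therefore reads as the limit of > 1000 ug/mL in this assay, at which 3 of the 3 values shown sit.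

The change from compound 2 to compound 4 is tert-butyl in place of phenyl on a nitrogen on an aromatic ring, which also reads as anilino to (tert-butyl)amino.

Two measured steps lie nearest. One is a step that the two limits leave unreadable from compound 1 to compound 3, with anilino in place of fluoro on an aromatic carbon. The other is a step that the two limits leave unreadable from compound 2 to compound 3, with fluoro in place of chloro on an aromatic carbon. Neither has a readable size, and neither alters the phenyl on the nitrogen.

No step beyond the scatter is therefore expected in this assay, and any number that did emerge could only point towards stronger inhibition. The expected step is a number no higher from compound 2 to compound 4 (the limit leaves the size open). For compound 4 the estimate is 1000 ug/mL, with an expected range from 250 ug/mL to 2000 ug/mL.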

Compound 4, half-maximal inhibitory concentration: 313 ug/mL
Compound 4: middle estimate off by 3.2-fold (0.50 log units), on the high side, within the range that was stated.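

In this assay, among the compounds shown here, tert-butyl in place of phenyl on the nitrogen gives an at least 3.1-fold lower number from compound 2 to compound 4 (0.50 log units; beyond the scatter), the only step with a readable size; the other steps, anilino in place of fluoro and fluoro in place of chloro, cannot be read. The group on this nitrogen is therefore a place where the read-out can come off the limit, something the changes on aromatic carbon did not show. For the compounds shown here, compound 4, at 313 ug/mL, holds the only number in the record. The step thus rests on one number set against a limit: the limit of > 1000 ug/mL in this assay, at which 3 of the 4 values shown sit.

Open, from the compounds shown here alone, is whether the drop belongs to tert-butyl itself or to the loss of the phenyl ring, which isopropyl, cyclohexyl or a longer chain such as n-butyl on the same nitrogen would help to separate. Also open, going by these compounds, is whether tert-butyl on this nitrogen gives a number of the same size when fluoro stands in place of the chloro of compound 4.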